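Series notes: fluoro in place of methoxy, compound 3

A few compounds are considered here, and "the series" means these few. Any claim that something is new, unique, unknown or untested is made for them only; others in the source may bear on it.

Two compounds of the series carry a number in a functional assay on COLO 205 cells (Homo sapiens) for cytotoxicity, read by MTT assay, with a stated time of 72 h; on this read-out lower numbers stand for stronger inhibition and higher numbers for weaker inhibition. Compound 1 `COc1cccc(/C=C/C(=O)Nc2cc(OC)c(OC)c(OC)c2)c1` gives 4200 nM. Compound 2 `COc1ccc(/C=C/C(=O)Nc2cc(C(=O)c3cc(OC)c(OC)c(OC)c3)ccc2OC)cc1` gives 10900 nM, the higher of the two numbers, and its gap to compound 1 lies beyond the usual scatter of repeat measurements. Going by the values given here, no pair of measured compounds differs in one place only, so no single structural change has a measured step attached to it.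

Compound 3 `COc1ccc(C(=O)c2cc(OC)c(OC)c(OC)c2)cc1NC(=O)/C=C/c1ccc(F)cc1` is not yet measured. It differs from compound 2 by fluoro in place of methoxy on an aromatic carbon; in words, fluoro in place of methoxy on an aromatic carbon, para to a large group. Among the compounds with values here, nothing among the measured compounds tests this change, so the step expected in this assay is a 1.2-fold lower number from compound 2 to compound 3 (0.08 log units; within the scatter), with no move beyond the scatter expected in either direction. On that basis compound 3 is estimated at 9000 nM in this assay, with an expected range from 3000 nM to 30000 nM; the width of that range reflects the absence of any measured step for this change.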

Compound 3, half-maximal inhibitory concentration: 3400 nM
The estimate for compound 3 lay 2.6-fold (0.42 log units) above the measured number, within the range that was stated.
By their numbers in this assay, from the lowest: compounds 3 and 1 (each within the scatter of the next); then compound 2.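

In this assay, going by these compounds alone, fluoro in place of methoxy on the aromatic carbon para to a large group gives a 3.2-fold lower number from compound 2 to compound 3 (0.51 log units; beyond the scatter), the first step tied to a single structural change and a modest one. This shows that the number responds to the group at this position, and that the 2-(4-methoxyphenyl)ethenyl of compound 2 can give way to the 2-(4-fluorophenyl)ethenyl of compound 3 with a gain in this read-out, although the change removes a hydrogen-bond acceptor and swaps two heavy atoms for one. No measurement shown bears on the reason for this step.

With a single pair at this position, the compounds shown cannot separate the effect of losing methoxy from that of gaining fluoro, and a plain hydrogen, chloro, or a dimethylamino group at the same place would be needed to show whether the step follows any trend. Going by these compounds, it also remains open whether the same exchange gives a step of similar size on the core of compound 1, where the methoxy group sits at a different place.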